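This account rests on a few compounds, and the source may have more. Where it says the series, first, only, none or still open, it means among the compounds named here.

Measured so far:
compound 1, `CCc1sc(CCc2cc(OC)cc(NCc3cc(Cl)cc(NC(=O)OC(C)C)c3)n2)nc1C`, gives 234 nM in an assay on cells for binding affinity to Neuropeptide Y receptor type 1 (Homo sapiens); on this read-out higher numbers stand for weaker inhibition and lower numbers for stronger inhibition;
compound 2, `CCOc1cc(CCc2nc(C)c(CC)s2)nc(NCc2cc(Cl)cc(NC(=O)OC(C)C)c2)c1`, gives 33 nM.

Compound 2 stands lowest of the two numbers; the one step shown, a 7.1-fold lower number from compound 1 to compound 2 (0.85 log units; beyond the scatter), lies beyond the scatter. Compound 3, `CCCCOc1cc(CCc2nc(C)c(CC)s2)nc(NCc2cc(Cl)cc(NC(=O)OC(C)C)c2)c1`, differs from compound 2 by ethyl in place of hydrogen on a saturated chain carbon, two bonds along the chain from an oxygen on an aromatic ring. Only a 7.1-fold lower number from compound 1 to compound 2 (0.85 log units; beyond the scatter) bears on this change, and it lengthened the same chain by less; a further lengthening is expected to give a smaller step in the same direction, or none beyond the scatter. Compound 3 is therefore expected to lie at 20 nM, with a range from 7 nM to 60 nM. The expected step is a 1.7-fold lower number from compound 2 to compound 3 (0.22 log units; within the scatter).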

Compound 3, half-maximal inhibitory concentration: 16 nM
Estimate against measurement, compound 3: 1.3-fold (0.10 log units) above; the range from low to high includes it.
By their numbers in this assay, from the lowest: compound 3; then compound 2; then compound 1.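

In this assay, the gain at this position does not stop at ethoxy: going on to butoxy gives a 2.1-fold lower number from compound 2 to compound 3 (0.31 log units; beyond the scatter), though the ethyl addition yields a smaller step than the earlier methyl addition. Taken from the methoxy end, the change to butoxy gives a 15-fold lower number from compound 1 to compound 3 (1.17 log units; beyond the scatter), so among these three compounds the number falls with each lengthening of the chain. Nothing available explains this fall. Going by these compounds, whether a longer chain such as hexyloxy would lower the number further or reverse the trend remains open. So does whether a chain ending in an amine or a carboxylic acid would hold the number.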